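The source may hold more compounds than are shown below. What is called first, only, known or untested is meant among the compounds shown, and "the series" means these compounds.

Measured so far in a functional assay on HeLa cells (Homo sapiens) for antiproliferative activity, read by sulforhodamine B assay, with a stated time of 48 h; on this read-out lower numbers stand for stronger inhibition and higher numbers for weaker inhibition:
compound 1, `O=S(=O)(Nc1nccs1)c1ccc(N/C(S)=N\c2ccnc3cc(C(F)(F)F)ccc23)cc1`, gives 95200 nM
compound 2, `Cc1ccnc(NS(=O)(=O)c2ccc(N/C(S)=N\c3ccnc4cc(C(F)(F)F)ccc34)cc2)n1`, gives 31000 nM

Within the data shown here, compound 2 holds the lower of the two numbers in this assay; the only other point is compound 1, and the single step, a 3.1-fold lower number from compound 1 to compound 2 (0.49 log units; beyond the scatter), is the whole of what the series shows so far. Compound 3, `Cc1cc(C)nc(NS(=O)(=O)c2ccc(N/C(S)=N\c3ccnc4cc(C(F)(F)F)ccc34)cc2)n1`, differs from compound 2 by methyl in place of hydrogen on an aromatic carbon. Among the measured compounds shown here, no measured pair exchanges a hydrogen for a methyl on this ring; the one step on record swaps the entire heteroaryl on the sulfonamide nitrogen and therefore bears only loosely on the present change. Adding a second methyl to a ring that already carries one is a smaller alteration than that swap, so the expectation in this assay is a step of a 1.2-fold lower number from compound 2 to compound 3 (0.09 log units; within the scatter), which is not expected to pass beyond the scatter. The estimated value for compound 3 in this assay is 25000 nM, with a range from 10000 nM to 65000 nM.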

Compound 3, half-maximal inhibitory concentration: 33000 nM
Beside the measured number, compound 3's estimate is 1.3-fold (0.12 log units) below it; measured number inside the range.
By their numbers in this assay, from the lowest: compounds 2 and 3 (each within the scatter of the next); then compound 1.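

In this assay, among these compounds, this is the first reading of methyl in place of hydrogen on an aromatic carbon next to the ring nitrogen, and the step is a 1.1-fold higher number from compound 2 to compound 3 (0.03 log units; within the scatter), so 4-methylpyrimidin-2-yl and 4,6-dimethylpyrimidin-2-yl cannot be told apart at this read-out. The separation from the 1,3-thiazol-2-yl compound survives the added methyl, with a 2.9-fold lower number from compound 1 to compound 3 (0.46 log units; beyond the scatter), so in these three compounds both pyrimidine groups on the sulfonamide nitrogen stand apart from the thiazole. Nothing available on these compounds bears on why the added methyl leaves the number within the scatter.

The compounds shown leave open whether this carbon tolerates only a methyl or would show the same flat result with an amine, a methoxy group or a longer chain such as propyl in its place. Also open, as far as these compounds go, is whether a change away from the sulfonamide substituent, such as chlorine in place of the trifluoromethyl on the shared core, would move the number in this assay further than any heteroaryl exchange seen here.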